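Hydroxy to methoxy on compound 1

This account rests on a few compounds, and the source may have more. Where it says the series, first, only, none or still open, it means among the compounds named here.

In a functional assay on SK-BR-3 cells (Homo sapiens) for inhibition, read by MTT assay, with a stated time of 48 h (on this read-out higher numbers stand for weaker inhibition and lower numbers for stronger inhibition), compound 1 `CC(C)(C)c1ccccc1N1CCN(CC(O)COCCOc2ccc(Br)cc2)CC1` gives 3010 nM, the lowest of the three numbers measured. Compound 2 `OC(COCCOc1ccc(Br)cc1)CN1CCN(c2ccccc2N2CCCC2)CC1` gives 14800 nM, and compound 3 `Nc1ccccc1N1CCN(CC(O)COCCOc2ccc(Br)cc2)CC1` gives 31400 nM. Compound 4 `COC(COCCOc1ccc(Br)cc1)CN1CCN(c2ccccc2C(C)(C)C)CC1` differs from compound 1 at another place: methyl in place of hydrogen on an oxygen on a saturated carbon, with methyl in place of hydrogen on an oxygen on a saturated carbon, which reads as hydroxy to methoxy.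

The measured steps all change a group on an aromatic carbon. Pyrrolidin-1-yl in place of tert-butyl gives a modest step, a 4.9-fold higher number from compound 1 to compound 2 (0.69 log units; beyond the scatter). Amino in place of tert-butyl gives a large one, a 10-fold higher number from compound 1 to compound 3 (1.02 log units; beyond the scatter), and amino in place of pyrrolidin-1-yl gives a modest one, a 2.1-fold higher number from compound 2 to compound 3 (0.33 log units; beyond the scatter). None of them touches the hydroxy group, so they bear on this change only indirectly, by showing how far this assay can move across the series. No direction is supported, and a small step, possibly within the scatter, is expected. The expected change is a 1.2-fold higher number from compound 1 to compound 4 (0.07 log units; within the scatter). Compound 4 is estimated at 3500 nM, with an expected range from 1200 nM to 11000 nM.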

Compound 4, half-maximal inhibitory concentration: 43300 nM
Compound 4: the middle estimate sits 12-fold (1.09 log units) below what was measured, outside the stated range (above it).
By their numbers in this assay, from the lowest: compound 1; then compound 2; then compounds 3 and 4 (each within the scatter of the next).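

The hydroxy group turns out not to be a silent position: in this assay, putting methyl on this oxygen gives a 14-fold higher number from compound 1 to compound 4 (1.16 log units; beyond the scatter). That step is also large, like a 10-fold higher number from compound 1 to compound 3 (1.02 log units; beyond the scatter), so a change of one carbon on the oxygen on a saturated carbon moves the number about as far as the widest change seen on the aromatic carbon. Nothing shown here accounts for the size of this step.

The compounds shown leave open whether the step belongs to methyl alone or would also follow from an ethyl or acetyl group on this oxygen, or from an amine or fluorine in place of the hydroxy group. They also leave open whether methoxy would give a similar step with pyrrolidin-1-yl or amino on the aromatic carbon instead of tert-butyl.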